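From Phenylpiperazine to Dimethoxybenzylamine on a Shared Core

This account rests on a few compounds, and the source may have more. Where it says the series, first, only, none or still open, it means among the compounds named here.

In a functional assay (aorta) with Rattus norvegicus as the target (on this read-out higher numbers stand for weaker inhibition and lower numbers for stronger inhibition), compound 2 (`CC(C)c1cn2ccccc2c1S(=O)(=O)c1ccc(OCCCN2CCN(c3ccccc3)CC2)cc1`) stands at 205 nM and so has the highest of the three numbers measured. Compound 3 (`CCCCN(CCCC)CCCCOc1ccc(S(=O)(=O)c2c(C(C)C)cn3ccccc23)cc1`) gives 20.2 nM and compound 1 (`COc1ccc(CN(C)CCCCOc2ccc(S(=O)(=O)c3c(C(C)C)cn4ccccc34)cc2)cc1OC`) gives 14.6 nM with both far lower than compound 2 and within the usual scatter of each other. Among the compounds with values here, compound 4 (`COc1ccc(CNCCCOc2ccc(S(=O)(=O)c3c(C(C)C)cn4ccccc34)cc2)cc1OC`) is still unmeasured and carries (3,4-dimethoxybenzyl)amino in place of 4-phenylpiperazin-1-yl on a saturated chain carbon, three bonds along the chain from an oxygen on an aromatic ring as its only change from compound 2. Within the data shown here, the one measured step at this place also removes 4-phenylpiperazin-1-yl: it is a 10-fold lower number from compound 2 to compound 3 (1.01 log units; beyond the scatter) and lies beyond the scatter. Compound 1 at 14.6 nM also holds a 3,4-dimethoxybenzyl group, but it differs from compound 4 in more than one place and is only a loose guide. A fall of similar size is therefore expected in this assay with a 6.8-fold lower number from compound 2 to compound 4 (0.83 log units; beyond the scatter) as the estimated step toward stronger inhibition. Compound 4 is estimated at 30 nM with an expected range from 9 nM to 100 nM for repeated measurements.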

Compound 4, half-maximal inhibitory concentration: 13 nM
For compound 4 the middle estimate is 2.3-fold (0.36 log units) above the measured one; the measured number falls inside the stated range.
By their numbers in this assay, from the lowest: compounds 4, 1 and 3 (each within the scatter of the next); then compound 2.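

In this assay, replacing 4-phenylpiperazin-1-yl with (3,4-dimethoxybenzyl)amino gives a 16-fold lower number from compound 2 to compound 4 (1.20 log units; beyond the scatter) and is thus a second large fall at this place on the chain, reached with a quite different group. Set against (dibutylamino)methyl, the same group gives a 1.6-fold lower number from compound 3 to compound 4 (0.19 log units; within the scatter) and lies within the scatter, so these two groups cannot be told apart here, even though only one of them carries an aromatic ring. Among these three compounds, then, compound 2 alone stands apart, and a single favourable group no longer accounts for the low numbers.

On these data alone, it remains open whether a benzylamino group without the two methoxy groups, or a small dimethylamino group, would keep the number this low. Nothing available here explains why 4-phenylpiperazin-1-yl gives the higher number.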